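The source may hold more compounds than are shown below. What is called first, only, known or untested is meant among the compounds shown, and "the series" means these compounds.

Compound 1 `CS/C(=N\C(=O)c1csc([N+](=O)[O-])c1)NC(=O)c1csc([N+](=O)[O-])c1` gives 78100 nM in a functional assay on MCF7 cells (Homo sapiens) for cytotoxicity, read by MTT assay, with a stated time of 72 h (a higher number here means a weaker inhibitor of growth, a lower number a stronger inhibitor of growth), and compound 2 `O=C(/N=C(/NC(=O)c1csc([N+](=O)[O-])c1)[Se]Cc1ccccc1)c1csc([N+](=O)[O-])c1` gives 54100 nM. The step of a 1.4-fold lower number from compound 1 to compound 2 (0.16 log units; within the scatter) sits within the scatter, so the two numbers cannot be told apart. Compound 3 `C[Se]/C(=N\C(=O)c1csc([N+](=O)[O-])c1)NC(=O)c1csc([N+](=O)[O-])c1` carries hydrogen in place of phenyl on a saturated chain carbon bound to a selenium atom. Among the measured compounds shown here, the only measured step that bears on this change is the one from compound 1 to compound 2, which also swapped a small group for a larger one at the same position and stayed within the scatter; compound 3 is therefore expected to show a 1.1-fold higher number from compound 2 to compound 3 (0.06 log units; within the scatter), no shift beyond the scatter, and an estimated 62000 nM ranging from 30000 nM to 125000 nM.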

Compound 3, concentration for total growth inhibition: 28100 nM
Compound 3: the middle estimate sits 2.2-fold (0.34 log units) above what was measured; measured number below the stated range.
By their numbers in this assay, from the lowest: compounds 3, 2 and 1 (each within the scatter of the next, the first and the last beyond it).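

Among the compounds shown here, with the methyl held constant, selenium in place of sulfur on the carbon with a double bond to nitrogen gives the first step beyond the scatter in this assay, a 2.8-fold lower number from compound 1 to compound 3 (0.44 log units; beyond the scatter), though a modest one. On selenium, benzyl to methyl gives a 1.9-fold lower number from compound 2 to compound 3 (0.28 log units; within the scatter), so these two groups cannot be told apart here. Nothing available accounts for the selenium step. Still open, going by these compounds, is how a longer chain or an amine on selenium would read, and whether benzyl on sulfur would show the same exchange.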